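The compounds below may be only part of what the source reports. "The series", "measured", "known", "first", "only" and "open" are said of these compounds alone.

In a functional assay on MCF7 cells (Homo sapiens) for cytotoxicity, read by MTT assay, with a stated time of 72 h; a higher number here means a weaker inhibitor, a lower number a stronger inhibitor:
- compound 1 `O=C(N/N=C/c1ccc(O)c(Br)c1)Nc1cc2c(Nc3ccc(F)c(Cl)c3)ncnc2cc1O[C@H]1CCOC1`: 2690 nM
- compound 2 `COc1cc2ncnc(Nc3ccc(F)c(Cl)c3)c2cc1NC(=O)N/N=C/c1ccc([N+](=O)[O-])cc1`: 36800 nM
- compound 3 `COc1cc2ncnc(Nc3ccc(F)c(Cl)c3)c2cc1NC(=O)N/N=C/c1cc(OC)c(OC)c(OC)c1`: 30700 nM

Compound 3 lies within the scatter of compound 2, and compound 1 shows a clearly lower number than either. Compound 4 `COc1cc2ncnc(Nc3ccc(F)c(Cl)c3)c2cc1NC(=O)N/N=C/c1ccc(O)c(Br)c1` has 3-bromo-4-hydroxyphenyl in place of 3,4,5-trimethoxyphenyl on a carbon with a double bond to nitrogen. Among the measured compounds shown here, the only measured swap at this place, a 1.2-fold lower number from compound 2 to compound 3 (0.08 log units; within the scatter), suggests little change. Yet compound 1, at 2690 nM, carries the same 3-bromo-4-hydroxyphenyl on a different core, which hints at a lower number. A moderate fall is therefore expected, an estimated 2.6-fold lower number from compound 3 to compound 4 (0.41 log units; beyond the scatter) in this assay. The expected value for compound 4 is 12000 nM, within an estimated range of 3500 nM to 35000 nM.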

Compound 4, half-maximal inhibitory concentration: "not active" (no number reported)
The entry for compound 4 holds no number, and the estimate cannot be compared.
By their numbers in this assay, from the lowest: compound 1; then compounds 3 and 2 (each within the scatter of the next).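

In this assay, among the compounds shown here, compound 4 is reported only as not active, without a number, so no step from compound 3 can be read. No evidence here explains this result. As far as these compounds go, how 3-bromo-4-hydroxyphenyl compares numerically with 3,4,5-trimethoxyphenyl on this core remains open.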